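Permeability notes: from compound 2 to compound 3

A few compounds are considered here, and "the series" means these few. Any claim that something is new, unique, unknown or untested is made for them only; others in the source may bear on it.

- Compound 1 `NC/C=C/CN(C[C@H]1Cc2ncccc2CN1)[C@H]1CCCc2cccnc21`: 15 nm/s
- Compound 2 `NC(=O)NC/C=C/CN(C[C@H]1Cc2ncccc2CN1)[C@H]1CCCc2cccnc21`: 2 nm/s

In an ADME assay for permeability, using PAMPA, with a stated time of 4 h, at pH 7.4 (on this read-out lower numbers stand for lower permeability and higher numbers for higher permeability), compound 2 stands lowest of the two measured compounds at 2 nm/s and compound 1 gives 15 nm/s with a gap beyond the scatter. Compound 3 `CCN(CC)CCCCN(C[C@H]1Cc2ncccc2CN1)[C@H]1CCCc2cccnc21` is the next to be read. The change is a group of 8 heavy atoms (7 carbon, 1 nitrogen; no ring) in place of a group of 7 heavy atoms (4 carbon, 2 nitrogen, 1 oxygen; no ring), on a saturated chain carbon bound to an amine nitrogen and the entering group is 3-(diethylamino)propyl.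

For the measured compounds named here, compound 3 has no carbamoyl, so the one measured step that bears on it is a 7.5-fold lower number from compound 1 to compound 2 (0.88 log units; beyond the scatter) with carbamoyl in place of hydrogen on an amine nitrogen. That step is modest and beyond the scatter. Going by the values given here, no measured compound carries 3-(diethylamino)propyl, so the effect of the entering group itself remains open. A rise of similar size to the measured step is expected in this assay on removal of the carbamoyl. The estimated step is a 7.5-fold higher number from compound 2 to compound 3 (0.88 log units; beyond the scatter) in this read-out. The estimate for compound 3 is 15 nm/s with an expected range of 4 nm/s to 60 nm/s as a wide working range.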

Compound 3, apparent permeability: 240 nm/s
Estimate against measurement, compound 3: 16-fold (1.20 log units) below; the measured number lies above the stated range.
By their numbers in this assay, from the lowest: compound 2; then compound 1; then compound 3.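

In this assay, the place on a saturated chain carbon bound to an amine nitrogen can move the number much further than the carbamoyl change alone suggested: the exchange for 3-(diethylamino)propyl gives a 120-fold higher number from compound 2 to compound 3 (2.08 log units; beyond the scatter) as a large step. The same group in place of 3-aminoprop-1-en-1-yl gives a 16-fold higher number from compound 1 to compound 3 (1.20 log units; beyond the scatter) and is also large, so loss of the carbamoyl does not account for the whole rise. The first pair showed only a fall at this place, whereas the three compounds now show that the number can also rise well past that of compound 1, leaving compound 3 the highest of the set, with both its steps beyond the scatter.

Still open, on these data alone, is whether the rise follows the diethylamino group, the saturated chain or the chain length, and a 3-aminopropyl group, a longer chain ending in diethylamino, or a morpholine at the chain end would help separate these. No measurement at hand explains the size of either step.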